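One Hydrazone Swap on a Shared Core in Gastric Cancer Cells

The source may report more compounds than this note shows. Statements on the series, on what has been measured and on what is new or still open speak of the compounds shown alone.

Measured compounds:
compound 1 `CCCSc1nc(N/N=C/c2ccccc2F)c2nnn(Cc3ccccc3)c2n1` — > 64000 nM
compound 2 `CCCSc1nc(N/N=C/c2cc(OC)c(OC)c(OC)c2)c2nnn(Cc3ccccc3)c2n1` — 9410 nM
compound 3 `CCCSc1nc(N/N=C/c2cccnc2)c2nnn(Cc3ccccc3)c2n1` — 38100 nM

In a functional assay on MGC-803 cells (Homo sapiens) for antiproliferative activity, read by MTT assay, with a stated time of 72 h (a higher number here means a weaker inhibitor, a lower number a stronger inhibitor), compound 1 gives > 64000 nM. That figure is a limit of the assay, not a measured number. Compound 1 therefore sits at the limit of > 64000 nM in this assay, at which 1 of the 3 values shown sits, the weak end of the three values shown. Compound 2, in this assay, gives 9410 nM. Compound 3 gives 38100 nM. Among the measured compounds shown here, the one measured step that starts from compound 1 is an at least 1.6-fold lower number from compound 1 to compound 3 (0.22 log units; that floor lies within the scatter); since compound 1 is only a limit, the true size of that step is unknown and its floor lies within the scatter.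

Compound 4 `CCCSc1nc(N/N=C(\C)c2ccccc2O)c2nnn(Cc3ccccc3)c2n1` is the unmeasured member. It differs from compound 1 in one place: a group of 10 heavy atoms (8 carbon, 1 nitrogen, 1 oxygen; one six-membered aromatic ring of carbon only) in place of a group of 9 heavy atoms (7 carbon, 1 nitrogen, 1 fluorine; one six-membered aromatic ring of carbon only), on a nitrogen on an aromatic ring. For the measured compounds named here, only the step from compound 1 to compound 3 bears on this change, and it shows merely that moving away from the 2-fluorophenyl group can give a lower number. The change in compound 4 is larger than that one, so the direction is expected to be downward, but the size is uncertain. Compound 4 is accordingly expected to show a step of an at least 2.1-fold lower number from compound 1 to compound 4 (0.32 log units; beyond the scatter). The estimate for compound 4 in this assay is 30000 nM, with a range from 7000 nM to 120000 nM.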

Compound 4, half-maximal inhibitory concentration: 2310 nM
Estimate against measurement, compound 4: 13-fold (1.11 log units) above; measured number below the stated range.
By their numbers in this assay, from the lowest: compound 4; then compound 2; then compound 3. At a limit, above all of these: compound 1.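

In this assay the group on the nitrogen on the aromatic ring proves able to carry a large change: an at least 27-fold lower number from compound 1 to compound 4 (1.44 log units; beyond the scatter) and so clears the scatter, which the earlier step at this place did not. The result does not rest on the limit alone, since the step between two measured numbers is also large and beyond the scatter: a 16-fold lower number from compound 3 to compound 4 (1.22 log units; beyond the scatter). Going by these compounds, compound 1 stands at a limit of the assay, so the first of these steps gives only a floor and its true size stays unknown: the limit of > 64000 nM in this assay, at which 1 of the 4 values shown sits.

The entering group differs from the 2-fluorophenyl group it replaces in more than one way, with an oxygen in place of the fluorine, one more carbon and 1 hydrogen-bond donor against none, and the compounds shown do not separate these differences. They also leave open whether an amine or a carboxylic acid in this group would lower the number further, and whether the same change would hold with a chain other than the propyl chain or on a core without the benzyl group.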